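Extending the aniline substituent in a thiourea series

The source may report more compounds than this note shows. Statements on the series, on what has been measured and on what is new or still open speak of the compounds shown alone.

Compound 1 `NS(=O)(=O)c1ccc(NC(=S)Nc2ccc3ncnc(Nc4ccc(F)c(Cl)c4)c3c2)cc1` gives 37600 nM in a functional assay on A-431 cells (Homo sapiens) for antiproliferative activity, read by MTT assay, with a stated time of 72 h; a higher number here means a weaker inhibitor, a lower number a stronger inhibitor.
Compound 2 `NS(=O)(=O)c1ccc(NC(=S)Nc2ccc3ncnc(Nc4ccc(F)c(Br)c4)c3c2)cc1` gives 18200 nM in this assay.
Compound 3 `CCc1ccc(Nc2ncnc3ccc(NC(=S)Nc4ccc(S(N)(=O)=O)cc4)cc23)cc1` gives 38400 nM in this assay.

Compound 1 stands second highest of these three numbers; compound 3 lies within the scatter of it, while a 2.1-fold lower number from compound 1 to compound 2 (0.32 log units; beyond the scatter) is the only shift beyond the scatter. Compound 4 `NS(=O)(=O)c1ccc(NC(=S)Nc2ccc3ncnc(Nc4ccc(OCc5cccc(F)c5)c(Cl)c4)c3c2)cc1` differs from compound 1 by (3-fluorobenzyl)oxy in place of fluoro on an aromatic carbon. For the measured compounds named here, no measured step swaps this particular group, but the changes made so far on the same aromatic ring, a 1.0-fold higher number from compound 1 to compound 3 (0.01 log units; within the scatter) and a 2.1-fold higher number from compound 2 to compound 3 (0.32 log units; beyond the scatter), moved this assay only modestly, so at most a small step in either direction is expected, quite possibly none beyond the scatter. Compound 4 is therefore estimated at 25000 nM, with a range from 8000 nM to 80000 nM, so that a 1.5-fold lower number from compound 1 to compound 4 (0.18 log units; within the scatter) is expected.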

Compound 4, half-maximal inhibitory concentration: 29500 nM
Estimate against measurement, compound 4: 1.2-fold (0.07 log units) below, within the range that was stated.
By their numbers in this assay, from the lowest: compounds 2, 4, 1 and 3 (each within the scatter of the next, the first and the last beyond it).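

Replacing the fluoro, para to a large group, with (3-fluorobenzyl)oxy adds an aromatic ring and 9 heavy atoms, yet a 1.3-fold lower number from compound 1 to compound 4 (0.11 log units; within the scatter) is all that follows in this assay. For the compounds shown here, this carbon therefore accepts a much larger group with no shift beyond the scatter, something no earlier step could show. Nothing measured here explains this tolerance.

On these data alone, whether a methoxy group or an amine on this carbon would behave the same remains open. So does whether the fluoro on the added benzyl ring matters.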